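A few compounds are considered here, and "the series" means these few. Any claim that something is new, unique, unknown or untested is made for them only; others in the source may bear on it.

Compound 3, `COc1cc(C(=O)NC2CCN(C)CC2)ccc1Nc1ncc2c(n1)N(C1CCCC1)[C@H](C)C(=O)N2C`, gives 1.1 nM in an assay on isolated protein for inhibition of serine/threonine-protein kinase PLK1 (Homo sapiens), read by Z'-LYTE (a higher number here means a weaker inhibitor, a lower number a stronger inhibitor), the lowest of the three numbers recorded. Compound 1, `CC[C@@H]1C(=O)N(C)c2cnc(Nc3ccc(C(=O)NC4CCN(C)CC4)cc3OC)nc2N1C1CCCCC1`, gives 4 nM in this assay, and compound 2, `CC[C@@H]1C(=O)N(C)c2cnc(Nc3ccc(C(=O)NC4CCN(C)CC4)cc3OC)nc2N1C(C)C`, gives 4 nM; both stand beyond the scatter above compound 3. Compound 4, `CCC[C@@H]1C(=O)N(C)c2cnc(Nc3ccc(C(=O)NC4CCN(C)CC4)cc3OC)nc2N1C1CCCC1`, differs from compound 3 by ethyl in place of hydrogen on a saturated chain carbon bound to a saturated ring carbon. Within the data shown here, no measured single step bears on this change: the one step recorded, no change at the digits printed from compound 1 to compound 2 (within the scatter), concerns the group on the ring nitrogen, and compounds 1 and 2 differ from compound 3 in two places at once. With nothing that points in either direction, compound 4 is expected to show a step of a 1.6-fold higher number from compound 3 to compound 4 (0.21 log units; within the scatter) that stays within the scatter. Compound 4 is therefore estimated at 1.8 nM, in a range from 0.6 nM to 6 nM.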

Compound 4, half-maximal inhibitory concentration: 9.9 nM
Estimate against measurement, compound 4: 5.5-fold (0.74 log units) below, outside the stated range (above it).
By their numbers in this assay, from the lowest: compound 3; then compounds 1 and 2 (each within the scatter of the next); then compound 4.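

Ethyl in place of hydrogen on this saturated chain carbon, which turns methyl into propyl, gives a 9.0-fold higher number from compound 3 to compound 4 (0.95 log units; beyond the scatter) in this assay. Among these compounds, this shows that the read-out is sensitive to a change at this position, whereas the one earlier step concerned only the group on the ring nitrogen and stayed within the scatter. Nothing available accounts for the size of this step. The compounds shown leave open how a longer chain, an amine or a carboxylic acid would read here, and whether the step would hold with cyclohexyl or isopropyl on the ring nitrogen.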